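The compounds below may be only part of what the source reports. "The series", "measured", "known", "first", "only" and "open" are said of these compounds alone.

In a functional assay on Z-138 cells (Homo sapiens) for antiproliferative activity, with a stated time of 72 h (a higher number here means a weaker inhibitor, a lower number a stronger inhibitor), compound 1 `Nc1ncnn2c([C@@H]3O[C@H](CO)[C@@H](O)[C@H]3O)cc(C#Cc3ccccc3)c12` gives 41400 nM. For compound 2 `Nc1ncnn2c([C@@H]3O[C@H](CO)[C@@H](O)[C@H]3O)cc(-c3ccccc3)c12` only a limit is recorded in this assay, > 100000 nM. The step of an at least 2.4-fold higher number from compound 1 to compound 2 (0.38 log units; beyond the scatter) rests on that limit (the limit of > 100000 nM in this assay, at which 1 of the 2 values shown sits). Compound 2 thus stands at the limit, the weaker of the two measured compounds. Compound 3 `Nc1ncnn2c([C@@H]3O[C@H](CO)[C@@H](O)[C@H]3O)cc(-c3ccccc3Cl)c12` differs from compound 2 by chloro in place of hydrogen on an aromatic carbon. Among the compounds with values here, no measured step bears on this change; the single measured step concerns the phenyl group itself. For compound 3 the expected step of a number no higher from compound 2 to compound 3 (the limit leaves the size open) is therefore none beyond the scatter, and its value in this assay is estimated at 100000 nM, between 30000 nM and 300000 nM, most likely again reported only as a limit.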

Compound 3, half-maximal inhibitory concentration: 76100 nM
Compound 3: the middle estimate sits 1.3-fold (0.12 log units) above what was measured; the measured number falls inside the stated range.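

Chloro in place of hydrogen on the phenyl ring, ortho to a large group, gives a floor only (an at least 1.3-fold lower number from compound 2 to compound 3 (0.11 log units; that floor lies within the scatter)), so the size of this change stays unfixed. Within the data shown here, with 2-chlorophenyl in place of 2-phenylethynyl (a 1.8-fold higher number from compound 1 to compound 3 (0.26 log units; within the scatter)), phenylethynyl is no longer the only group at this position that gives a number in this assay without a limit. Compound 2 stands only as a limit: the limit of > 100000 nM in this assay, at which 1 of the 3 values shown sits.

As far as these compounds go, what a fluoro, a methoxy or an amine would give at this place stays open. From the compounds shown here alone, whether chloro elsewhere on the phenyl ring would read the same also stays open.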